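Replacing methylsulfonyl with 3-fluoro-1H-pyrazol-1-yl in compound 2

This account rests on a few compounds, and the source may have more. Where it says the series, first, only, none or still open, it means among the compounds named here.

Of the compounds shown here, three have so far been measured in a physicochemical assay for lipophilicity, at pH 7.4; a higher number here means a more lipophilic compound, a lower number a more polar compound. Compound 1 (`CS(=O)(=O)Nc1c(Cl)ccc2c1CCCC2c1ncc[nH]1`) gives 1.5, compound 2 (`CS(=O)(=O)Cc1cccc2c1CCC2c1ncc[nH]1`) gives 0.7, and compound 3 (`COCc1cccc2c1CC[C@H]2c1ncc[nH]1`) gives 1.8. Compound 2 is thus the lowest of the three, and the other two stand above it by more than the usual scatter.

Compound 4 (`Fc1ccn(Cc2cccc3c2CCC3c2ncc[nH]2)n1`) has not yet been measured. It differs from compound 2 in one place: 3-fluoro-1H-pyrazol-1-yl in place of methylsulfonyl on a saturated chain carbon bound to an aromatic carbon. In words, 3-fluoro-1H-pyrazol-1-yl stands in place of methylsulfonyl on a saturated chain carbon bound to an aromatic carbon.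

Among the compounds with values here, no measured pair shows this change on its own, so the expectation rests on loose comparisons. Compound 3, which has no methylsulfonyl, gives 1.8, well clear of compound 2 at 0.7. Yet compound 1, which does carry methylsulfonyl, gives 1.5, and it also differs from compound 2 elsewhere, so the comparison can offer only weak support. An upward move beyond the scatter is nevertheless expected, with the estimated step being a number 1.30 log units higher from compound 2 to compound 4 (beyond the scatter). In this assay, the estimate for compound 4 is 2, with the expected range running from 1.5 to 2.5.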

Compound 4, distribution coefficient: 2.4
Beside the measured number, compound 4's estimate is 0.40 log units below it; the range from low to high includes it.
By their numbers in this assay, from the lowest: compound 2; then compounds 1 and 3 (each within the scatter of the next); then compound 4.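

Within the data shown here, compound 2 and compound 4 form the first pair in this set that differs in one place, and it isolates the change at this position: in this assay, 3-fluoro-1H-pyrazol-1-yl in place of methylsulfonyl on a saturated chain carbon bound to an aromatic carbon gives a number 1.70 log units higher from compound 2 to compound 4 (beyond the scatter), a large step with the rest of the molecule unchanged. The groups have the same counts of hydrogen-bond donors and acceptors and neither has a net charge, so this large step occurs with those counts level, while the entering group has more heavy atoms and brings a five-membered aromatic ring. Nothing available bears on why the number moves, so the pair gives the size of the step and not its cause.

The compounds shown leave open how the step divides between the ring and its fluorine, a question that a plain 1H-pyrazol-1-yl on the same carbon would address. Also open, as far as these compounds go, are whether a step of this size would recur on the core of compound 1, and where an amine or a carboxylic acid at this place would fall in this assay.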